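Swapping methoxy for trifluoromethyl on a weakly active acid

The compounds below may be only part of what the source reports. "The series", "measured", "known", "first", "only" and "open" are said of these compounds alone.

Of the compounds shown here, two that share a core have been measured in a functional assay on Hep 3B2 cells (Homo sapiens) for antiproliferative activity, read by MTT assay, with a stated time of 24 h, tested at 0.14 ug/mL; a lower number here means a weaker effect, a higher number a stronger effect of the compound at the concentration tested. Compound 1, `Cc1c(C(=O)Nc2c(F)cc(-c3cccc(F)c3)cc2F)nc2ccc(C(F)(F)F)cc2c1O`, carries a hydroxyl group and a trifluoromethyl group on its core; in this assay compound 1 gives 2.65%. Compound 2, `COc1ccc2nc(C(=O)Nc3c(F)cc(-c4cccc(F)c4)cc3F)c(C)c(C(=O)O)c2c1`, instead carries a carboxylic acid and a methoxy group; in this assay compound 2 gives 0.02%. These two numbers lie within the usual scatter of each other, so compound 2 cannot be placed above or below compound 1: both show essentially no effect at the concentration tested.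

The next compound, compound 3, `Cc1c(C(=O)Nc2c(F)cc(-c3cccc(F)c3)cc2F)nc2ccc(C(F)(F)F)cc2c1C(=O)O`, keeps the carboxylic acid of compound 2 and differs from it in one place: trifluoromethyl in place of methoxy on an aromatic carbon. Compound 1 already holds a trifluoromethyl at that position and shows no stronger effect than compound 2, so no step beyond the scatter is expected from compound 2 to compound 3 in this assay.

The expected step from compound 2 to compound 3 is therefore a number 1.5 percentage points higher from compound 2 to compound 3 (within the scatter). Compound 3 is estimated to give 1.5% in this assay, with a range from -8% to 11%.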

Compound 3, a percentage reported as inhibition, at one concentration (the size of the read-out at that concentration, not a potency): 2.13%
Compound 3: the middle estimate sits 0.6 percentage points below what was measured; the range from low to high includes it.
By their numbers in this assay, from the lowest: compounds 2, 3 and 1 (each within the scatter of the next).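

With the carboxylic acid held in place, trifluoromethyl in place of methoxy on this aromatic carbon gives a number 2.1 percentage points higher from compound 2 to compound 3 (within the scatter) in this assay, so this direct one-place comparison detects no effect of the swap at the concentration tested. Compound 3 also links to compound 1 with trifluoromethyl kept in place: carboxy in place of hydroxy on an aromatic carbon gives a number 0.5 percentage points lower from compound 1 to compound 3 (within the scatter), so this second change also has no detectable effect in this read-out. Nothing available here offers an explanation for how closely these numbers agree.

All three compounds show essentially no effect at this single concentration, so these results cannot tell whether either change would matter under conditions where the compounds had a clear effect. On these data alone, it also remains open whether an amine or a longer chain on the aromatic carbon that carries methoxy or trifluoromethyl, or an amide in place of the carboxylic acid, would give a number beyond the scatter of these three.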